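Amine variation at the chain carbon of the shared core

The source may hold more compounds than are shown below. What is called first, only, known or untested is meant among the compounds shown, and "the series" means these compounds.

Compound 1 `CCCN(CCC)CC(C1CCCCC1)N1CCN(C(=O)[C@@H]2CN(C(C)(C)C)C[C@H]2c2ccc(F)cc2F)CC1` is the starting point here. In a functional assay on CHO cells for agonist activity at Melanocortin receptor 4 (Homo sapiens), read by cAMP accumulation (on this read-out lower numbers stand for an effect already at smaller amounts and higher numbers for an effect only at larger amounts of compound), compound 1 gives 710 nM; this is the only number shown for it, as two further entries returned no single value. Compound 2 `CC(=O)N(CC(C1CCCCC1)N1CCN(C(=O)[C@@H]2CN(C(C)(C)C)C[C@H]2c2ccc(F)cc2F)CC1)C(C)C` carries an acetyl isopropylamino group in the same place and gives 25 nM; 50 nM (2 entries) in this assay, the spread of its repeated entries the several entries of compound 2 in this assay, 25 nM; 50 nM (2 entries) lying within the usual scatter. Compound 3 `CC(C)N(CC(C1CCCCC1)N1CCN(C(=O)[C@@H]2CN(C(C)(C)C)C[C@H]2c2ccc(F)cc2F)CC1)C(=O)c1cccnn1` gives 9.1 nM; 5.4 nM (2 entries), again with repeated entries the several entries of compound 3 in this assay, 9.1 nM; 5.4 nM (2 entries) that agree within the scatter. No pair of these compounds differs in a single place, so their numbers are read side by side and not as steps.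

Compound 4 `CC(C)NCC(C1CCCCC1)N1CCN(C(=O)[C@@H]2CN(C(C)(C)C)C[C@H]2c2ccc(F)cc2F)CC1` is not yet measured. It differs from compound 1 by isopropylamino in place of dipropylamino on a saturated chain carbon, two bonds along the chain from an amine nitrogen in a ring and a saturated ring carbon. Among the compounds with values here, with no measured step of this kind, the size and direction of the change are uncertain; a modest move toward lower concentrations, possibly beyond the scatter, is expected but not assured. Compound 4 is estimated at 300 nM, with a range of 60 nM to 1500 nM, which means an expected step of a 2.4-fold lower number from compound 1 to compound 4 (0.37 log units; beyond the scatter).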

Compound 4, half-maximal effective concentration: 240 nM
Compound 4: the middle estimate sits 1.3-fold (0.10 log units) above what was measured, within the range that was stated.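

In this assay, within the data shown here, the change from dipropylamino to isopropylamino on this saturated chain carbon gives a 3.0-fold lower number from compound 1 to compound 4 (0.47 log units; beyond the scatter), the first single-place step and the first direct sign that the amine group at this position affects the read-out. The step combines two differences: isopropylamino has fewer heavy atoms than dipropylamino, and it carries a hydrogen-bond donor that dipropylamino lacks. Nothing at hand bears on why the number falls, as the only supporting data are repeated entries for other compounds.

The compounds shown leave open which of the two differences accounts for the step. Propylamino, dimethylamino or an unsubstituted primary amine at the same place would help separate heavy-atom count from the presence of the hydrogen-bond donor.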